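The compounds below may be only part of what the source reports. "The series", "measured", "known", "first", "only" and "open" are said of these compounds alone.

Measured compounds:
compound 1 `O=C(NCCSCc1ccccc1)n1c(=O)oc2ccccc21` — 65 nM
compound 2 `O=C(NCCCCc1cccs1)n1c(=O)oc2ccccc21` — 37 nM
compound 3 `O=C(c1ccc(Cl)cc1)c1ccc2c(c1)oc(=O)n2C(=O)NCCCCc1ccccc1` — 14 nM

All three were tested in an assay on HEK293 cells for inhibition of acid ceramidase (Homo sapiens), with a stated time of 10 min; a lower number here means a stronger inhibitor, a higher number a weaker inhibitor. Compound 2 has the second highest number of the three, and the numbers of compound 1 and compound 2 lie within the usual scatter of each other, so nothing separates them. Compound 3, which carries a larger substituted core, gives a lower number than compound 2, and that gap lies beyond the scatter.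

Compound 4 `COc1ccc(CCCCNC(=O)n2c(=O)oc3ccccc32)cc1` shares the core and the chain of compound 2 and differs in one place: 4-methoxyphenyl in place of thiophen-2-yl on a saturated chain carbon, four bonds along the chain from an amide-type nitrogen. For the measured compounds named here, no measured pair shows this particular exchange, so its effect is unknown; the three measured compounds all have an aromatic group at the end of a chain of similar length and all land in a narrow band, which suggests the group at the chain end matters little here.

Compound 4 is therefore expected to give about 40 nM in this assay, with a range from 15 nM to 110 nM. The expected step of a 1.1-fold higher number from compound 2 to compound 4 (0.03 log units; within the scatter) is essentially none beyond the scatter.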

Compound 4, half-maximal inhibitory concentration: 63 nM
The estimate for compound 4 lay 1.6-fold (0.20 log units) below the measured number; the measured number falls inside the stated range.
By their numbers in this assay, from the lowest: compound 3; then compounds 2, 4 and 1 (each within the scatter of the next).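

For the compounds shown here, this is the first comparison in which only the group at the end of the chain differs. In this assay, 4-methoxyphenyl in place of thiophen-2-yl on a saturated chain carbon, four bonds along the chain from an amide-type nitrogen, gives a 1.7-fold higher number from compound 2 to compound 4 (0.23 log units; within the scatter), so this exchange of one aromatic ring for another, larger by heavy atoms, does not separate the two compounds. No measurement at hand offers an explanation for this result.

The compounds shown leave open whether this position would accept something other than an aromatic ring, such as an amine or a carboxylic acid at the chain end. They also leave open how a longer chain would read out, and whether the same exchange would behave alike on the substituted core of compound 3.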